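A few compounds are considered here, and "the series" means these few. Any claim that something is new, unique, unknown or untested is made for them only; others in the source may bear on it.

Working notes on the series built on the shared core of compound 1 (`Oc1ccccc1-c1cc(-c2ccccc2F)cc(-c2ccccc2O)n1`), read in a functional assay on HeLa cells (Homo sapiens) for inhibition; a higher number here means a weaker inhibitor, a lower number a stronger inhibitor. Compound 1 gives > 50000 nM, which is a limit of the assay and not a number. Compound 2 (`Oc1ccccc1-c1cc(-c2ccc(F)cc2)cc(-c2ccccc2O)n1`) gives > 50000 nM, also a limit, and so stands at the limit of > 50000 nM in this assay, at which 2 of the 3 values shown sit. Compound 3 (`Oc1ccccc1-c1cc(-c2ccccc2C(F)(F)F)cc(-c2ccccc2O)n1`) gives a true number, 5800 nM.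

Compound 4 (`Oc1ccccc1-c1cc(-c2ccc(OC(F)(F)F)cc2)cc(-c2ccccc2O)n1`) follows from compound 2 with trifluoromethoxy in place of fluoro on an aromatic carbon, para to a large group: trifluoromethoxy in place of fluoro on an aromatic carbon.

Among the measured compounds shown here, two measured steps bear on this change: an at least 8.6-fold lower number from compound 1 to compound 3 (0.93 log units; beyond the scatter) and an at least 8.6-fold lower number from compound 2 to compound 3 (0.93 log units; beyond the scatter). Each is anchored on a limit, so its true size is open. Neither is the change at hand, since compound 3 carries trifluoromethyl, not trifluoromethoxy, and on a different phenyl pattern from compound 4. For the measured compounds named here, the only guide to direction is compound 3 at 5800 nM. Going by the values given here, compound 4 is therefore expected to give a lower number than compound 2 in this assay, though probably a smaller move than the one to compound 3. The expected step is an at least 3.3-fold lower number from compound 2 to compound 4 (0.52 log units; beyond the scatter). For compound 4 the estimated value is 15000 nM, with an expected range from 4000 nM to 50000 nM. A further reading at the limit remains a real possibility.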

Compound 4, half-maximal inhibitory concentration: > 50000 nM
Compound 4: only a limit was reported; the forecaster's own chance of this, stated with the estimate: 35%; at least 3.3-fold (0.52 log units) between middle value and limit.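

In this assay, among the compounds shown here, compound 2 and compound 4 each give only a limit of the assay and not a number, so no step between them can be read. The compounds shown leave open whether trifluoromethoxy in place of fluoro on this phenyl ring changes the number at all, and in which direction.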